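The source may hold more compounds than are shown below. What is called first, only, known or untested is meant among the compounds shown, and "the series" means these compounds.

Measured compounds in an ADME assay on MT4 cells (Homo sapiens) for cytotoxicity, read by MTT assay; on this read-out lower numbers stand for higher toxicity in this test and higher numbers for lower toxicity in this test:
compound 1 `Cc1ccc(N(C(=O)c2cccc([N+](=O)[O-])c2)C(=S)OCCN2C(=O)c3ccccc3C2=O)cc1`, giving 100000 nM
compound 2 `O=C1c2ccccc2C(=O)N1CCOC(=S)N(C(=O)c1ccc(Cl)c(Cl)c1)c1ccccc1`, giving 52000 nM
compound 3 `O=C1c2ccccc2C(=O)N1CCOC(=S)N(C(=O)c1ccc(F)cc1F)c1ccc(Cl)cc1`, giving 52000 nM

Compound 3 stands level with compound 2 at the digits shown, and its number sits within the usual scatter of the number for compound 1, so the three measured compounds cannot be told apart on this read-out. Compound 4 `Cc1cc(C(=O)N(C(=S)OCCN2C(=O)c3ccccc3C2=O)c2ccc(Cl)cc2)c(C)o1` has not yet been measured in this assay. It differs from compound 3 in one place: 2,5-dimethylfuran-3-yl in place of 2,4-difluorophenyl on a carbonyl carbon. Within the data shown here, no comparable step between measured compounds is available, and the three numbers so far spread only within the scatter, so no change beyond the scatter is expected from compound 3 to compound 4, that is a 1.2-fold higher number from compound 3 to compound 4 (0.06 log units; within the scatter). Compound 4 is therefore estimated at 60000 nM, within a range of 30000 nM to 120000 nM.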

Compound 4, half-maximal cytotoxic concentration: 40000 nM
For compound 4 the middle estimate is 1.5-fold (0.18 log units) above the measured one; the measured number falls inside the stated range.
By their numbers in this assay, from the lowest: compounds 4, 2, 3 and 1 (each within the scatter of the next, the first and the last beyond it).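

In this assay the change on a carbonyl carbon gives a 1.3-fold lower number from compound 3 to compound 4 (0.11 log units; within the scatter) and this lies within the scatter. Among these compounds, a five-membered aromatic ring with one hetero atom and one hydrogen-bond acceptor thus takes the place of a six-membered aromatic ring of carbon only with no step that can be told from repeat measurement. No available measurement accounts for this result. Going by these compounds, it remains open whether a group of another kind on this carbonyl carbon, such as a carboxylic acid or a longer alkyl chain, would give a step beyond the scatter.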